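The source may report more compounds than this note shows. Statements on the series, on what has been measured and on what is new or still open speak of the compounds shown alone.

Working notes on the series. Compound 1 `CN(C(=O)NC(=O)c1ccc(Cl)cc1Cl)c1nc(C(F)(F)F)c(C(=O)N/N=C/c2cccc(C(F)(F)F)c2)s1` was tested in a functional assay on HeLa cells (Homo sapiens) for inhibition, read by MTT assay, with a stated time of 72 h (on this read-out lower numbers stand for stronger inhibition and higher numbers for weaker inhibition), and gives 9.6 ug/mL. Compound 2 `CN(C(=O)NC(=O)c1ccc(Cl)cc1Cl)c1nc(C(F)(F)F)c(C(=O)N/N=C/c2ccc(C(F)(F)F)cc2)s1` carries 4-(trifluoromethyl)phenyl in place of 3-(trifluoromethyl)phenyl on a carbon with a double bond to nitrogen; in this assay compound 2 gives 7.99 ug/mL. The step of a 1.2-fold lower number from compound 1 to compound 2 (0.08 log units; within the scatter) is within the scatter, so compound 2 and compound 1 are not separable on these two numbers; compound 2 simply holds the lower of the two figures measured so far.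

Compound 3 `Cc1nc(N(C)C(=O)NC(=O)c2ccc(Cl)cc2Cl)sc1C(=O)N/N=C/c1ccc(C(F)(F)F)cc1` is not yet measured. It differs from compound 2 by methyl in place of trifluoromethyl on an aromatic carbon. For the measured compounds named here, no measured step touches this site of the core: the only step in hand, a 1.2-fold lower number from compound 1 to compound 2 (0.08 log units; within the scatter), concerns the trifluoromethylphenyl on the carbon doubly bonded to nitrogen and was within the scatter. The data give no guidance on the exchange at the five-membered ring. For compound 3 the expected step of a 1.3-fold higher number from compound 2 to compound 3 (0.10 log units; within the scatter) is therefore taken as none beyond the scatter, with a wide allowance. The estimate for compound 3 in this assay is 10 ug/mL, ranging from 4 ug/mL to 25 ug/mL.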

Compound 3, half-maximal inhibitory concentration: 20.3 ug/mL
Estimate against measurement, compound 3: 2.0-fold (0.31 log units) below; the range from low to high includes it.
By their numbers in this assay, from the lowest: compounds 2 and 1 (each within the scatter of the next); then compound 3.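

For the compounds shown here, the exchange of trifluoromethyl for methyl on the aromatic carbon next to the ring nitrogen gives, in this assay, a 2.5-fold higher number from compound 2 to compound 3 (0.40 log units; beyond the scatter) and is the only step so far that lies beyond the scatter. Going by these compounds alone, this shows that the ring carbon is not indifferent to the group it carries, whereas the one earlier step, a 1.2-fold lower number from compound 1 to compound 2 (0.08 log units; within the scatter), moved the trifluoromethyl on the phenyl group and could not be told apart from repeat variation. The step is modest and rests on a single pair, and no measurement in hand accounts for the higher number.

Open, on these data alone, is how other groups at this ring carbon would read, such as a chlorine, an ethyl chain or an amine, and whether any of them would fall on the trifluoromethyl side of methyl. Also open is whether the same exchange carries over to the 3-(trifluoromethyl)phenyl partner of compound 1, since among the compounds shown it is seen only with the 4-(trifluoromethyl)phenyl group.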